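Two Halogens on the Sulfonamide Aryl of Compound 2

This account rests on a few compounds, and the source may have more. Where it says the series, first, only, none or still open, it means among the compounds named here.

For the measured compounds named here, compound 2 `O=C(/C=C/c1cccnc1)NCCCCCCc1cccc(S(=O)(=O)Nc2ccccc2)c1` holds the lower of the two numbers so far recorded in a functional assay on MCF7 cells (Homo sapiens) for inhibition, read by CCK-8 assay, with a stated time of 72 h; a higher number here means a weaker inhibitor, a lower number a stronger inhibitor; compound 2 gives 0.63 nM. Its companion compound 1 `O=C(/C=C/c1cccnc1)NCCCCCc1ccc(S(=O)(=O)Nc2ccccc2)cc1` gives 95.7 nM in this assay, and the gap between the two lies well beyond the usual scatter of such measurements, so compound 2 is clearly the stronger inhibitor of the pair. Compound 3 `O=C(/C=C/c1cccnc1)NCCCCCCc1cccc(S(=O)(=O)Nc2ccc(F)c(Cl)c2)c1` has not yet been measured. The change from compound 2 to compound 3 is 3-chloro-4-fluorophenyl in place of phenyl on a sulfonamide nitrogen. Going by the values given here, no pair of measured compounds isolates a change of this kind, so the expectation rests on compound 2 alone. The step of a 1.6-fold higher number from compound 2 to compound 3 (0.20 log units; within the scatter) is expected to be small, most likely within the scatter or a mild weakening. Compound 3 is therefore estimated at 1 nM in this assay, with a range from 0.3 nM to 4 nM.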

Compound 3, half-maximal inhibitory concentration: 6.3 nM
For compound 3 the middle estimate is 6.3-fold (0.80 log units) below the measured one; measured number outside the range, above it.
By their numbers in this assay, from the lowest: compound 2; then compound 3; then compound 1.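

The phenyl on the sulfonamide nitrogen is not a silent position: in this assay, placing 3-chloro-4-fluorophenyl there gives a 10-fold higher number from compound 2 to compound 3 (1.00 log units; beyond the scatter). Of these two groups on this nitrogen, the unsubstituted phenyl of compound 2 therefore gives the stronger inhibitor, and the added chlorine and fluorine together carry a cost that lies beyond the scatter. No measurement shown here accounts for this weakening.

The change brings in both halogens at once, so the compounds shown do not tell whether 3-chlorophenyl or 4-fluorophenyl alone would account for the step. Also open, from the compounds shown here alone, is how this position would respond to a methoxy group, an amine or a carboxylic acid on the same aryl ring.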